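The compounds below may be only part of what the source reports. "The series", "measured", "known", "first", "only" and "open" are said of these compounds alone.

Measured compounds:
- compound 1, `Cc1cc(OCCCCCCC[N+]23CCN(CC2)CC3)cc(-n2cc(C(=O)Nc3cc(F)cc(F)c3)c(=O)c3ccc(N(C)C)nc32)c1`, giving 10.3% in an assay on LX2 cells for inhibition of COL1A1 promoter (Homo sapiens), read by a luciferase reporter, with a stated time of 24 h, tested at 20 uM; on this read-out higher numbers stand for a stronger effect at the one concentration tested and lower numbers for a weaker effect
- compound 2, `Cc1cc(OCCCCCCC[N+]2(C)CCCCC2)cc(-n2cc(C(=O)Nc3cc(F)cc(F)c3)c(=O)c3ccc(N(C)C)nc32)c1`, giving 46.8% in this assay

For the measured compounds named here, on these two numbers compound 2 stands highest, with compound 1 as its only neighbour, a number a number 36.5 percentage points higher from compound 1 to compound 2 (beyond the scatter). Compound 3, `Cc1cc(OCCCCCCC[n+]2ccccc2)cc(-n2cc(C(=O)Nc3cc(F)cc(F)c3)c(=O)c3ccc(N(C)C)nc32)c1`, has not yet been measured in this assay. It differs from compound 2 in one place: a group of 6 heavy atoms (5 carbon, 1 nitrogen; one six-membered aromatic ring with 1 hetero atom) in place of a group of 7 heavy atoms (6 carbon, 1 nitrogen; one six-membered non-aromatic ring with 1 hetero atom), on a saturated chain carbon, seven bonds along the chain from an oxygen on an aromatic ring.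

Going by the values given here, the only measured step that bears on this site is the one from compound 1 to compound 2, where exchanging one charged ring for another gave a change of a number 36.5 percentage points higher from compound 1 to compound 2 (beyond the scatter). That shows the group at the end of the chain can move the read-out by a large amount, but one step gives no direction for an aromatic ring at that site. The account therefore expects compound 3 to stay near compound 2, with a wide range to allow for the sensitivity this position has shown, and an expected step of a number 6.8 percentage points lower from compound 2 to compound 3 (within the scatter). The estimate for compound 3 in this assay is 40%, between 15% and 65%.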

Compound 3, a percentage reported as inhibition, at one concentration (the size of the read-out at that concentration, not a potency): 7.7%
Estimate against measurement, compound 3: 32.3 percentage points above; the measured number lies below the stated range.
By their numbers in this assay, from the lowest: compounds 3 and 1 (each within the scatter of the next); then compound 2.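

In this assay, replacing the non-aromatic six-membered ring at the end of the chain with the six-membered aromatic ring gives a number 39.1 percentage points lower from compound 2 to compound 3 (beyond the scatter), although the leaving and entering groups each carry a net charge of +1 and have the same hydrogen-bond counts. This shows that a net charge of +1 at this position does not on its own preserve the higher read-out, and that the ring type can matter even when these counts do not change. The further comparison gives a number 2.6 percentage points lower from compound 1 to compound 3 (within the scatter), so two structurally different end groups give read-outs that cannot be told apart, leaving compound 2 as the only one of the three that stands apart, while no measurement offered here explains the difference.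

The compounds shown leave open whether the higher read-out of compound 2 depends on its ring or could also be reached with an open-chain trimethylammonium group at the same place. They also leave open how an uncharged dimethylamino group or a longer chain would behave, and a single-concentration read-out gives no potency for any of these compounds.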